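A Second Chloro Group on a Shared Core

The source may report more compounds than this note shows. Statements on the series, on what has been measured and on what is new or still open speak of the compounds shown alone.

Compound 1 `CCCCCCC(CCO)n1cnc2c(Cl)ncnc21` and compound 2 `CCCCCCC(CCO)n1cnc2c(Cl)nc(Cl)nc21` share one core and differ in a single place, described as chloro in place of hydrogen on an aromatic carbon. In a functional assay on SW480 cells (Homo sapiens) for antiproliferative activity, read by MTT assay, with a stated time of 48 h (on this read-out higher numbers stand for weaker inhibition and lower numbers for stronger inhibition), compound 1 gives 16700 nM, and compound 2 gives 12400 nM, so that a 1.3-fold lower number from compound 1 to compound 2 (0.13 log units; within the scatter).

Compound 3 `CCCCCCCCC(CCO)n1cnc2c(N)ncnc21` carries a different core; the difference between the core of compound 3 and the core of compound 1 is not broken down here. In this assay compound 3 gives 20700 nM, a number that lies within the scatter of both compound 1 and compound 2.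

Compound 4 `CCCCCCCCC(CCO)n1cnc2c(N)nc(Cl)nc21` is not yet measured. It stands to compound 3 as compound 2 stands to compound 1, through (chloro in place of hydrogen on an aromatic carbon). The two places are not identical in their surroundings: in compound 1 the entering chloro group sits meta to a chloro group, whereas in compound 3 it sits meta to an amino group. The change is therefore the same kind of change rather than the same change.

Because a 1.3-fold lower number from compound 1 to compound 2 (0.13 log units; within the scatter), the expected step in this assay from compound 3 to compound 4 is of similar small size, a 1.4-fold lower number from compound 3 to compound 4 (0.14 log units; within the scatter), resting on that single measured pair alone. Compound 4 is therefore estimated at 15000 nM, with an expected range from 7500 nM to 30000 nM.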

Compound 4, half-maximal inhibitory concentration: 13100 nM
For compound 4 the middle estimate is 1.1-fold (0.06 log units) above the measured one; the range from low to high includes it.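

In this assay, the chloro group entering on an aromatic carbon of the second core gives a 1.6-fold lower number from compound 3 to compound 4 (0.20 log units; within the scatter), so this step, like the earlier one, stays within the scatter. Set side by side, the two steps agree: the same change on two cores in this assay, a 1.3-fold lower number (0.13 log units; within the scatter) from compound 1 to compound 2 and a 1.6-fold lower number (0.20 log units; within the scatter) from compound 3 to compound 4, 1.2-fold (0.07 log units) apart, within the scatter of two such steps. This shows that, on these two cores, the change carries over without any detectable difference in its size, but it does not show that the chloro group has a real effect on either core, since neither step rises above the scatter, and two pairs are too few to support a rule for the wider series or to tell which part of the difference between the cores, if any, matters.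

The compounds shown leave open whether another group in the same place, such as fluoro, bromo, methoxy or an amine, would give a step beyond the scatter. They also leave open whether the chloro step would stay the same on a core with a longer chain, or with a carboxylic acid in place of the hydroxyl group at the end of the side chain.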